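The compounds below may be only part of what the source reports. "The series", "measured", "known", "first", "only" and "open" are said of these compounds alone.

Compound 1 `COc1cc(-c2cc(/C=C/C(=O)c3ccc(N)cc3)[nH]n2)cc(OC)c1OC`: -89%
Compound 2 `COc1ccc(C(=O)/C=C/c2cc(-c3cc(OC)c(OC)c(OC)c3)n[nH]2)cc1OC`: -88%

Of these two numbers in a functional assay on BT-549 cells (Homo sapiens) for cytotoxicity, read by sulforhodamine B assay, with a stated time of 48 h, tested at 10 uM (a lower number here means a stronger effect, a higher number a weaker effect of the compound at the concentration tested), compound 2 gives -88%, and compound 1 gives -89%, the pair lying within the scatter of each other. Compound 3 `COc1ccc(C(=O)/C=C/c2cc(-c3cc(OC)c(OC)c(OC)c3)n[nH]2)cc1` differs from compound 2 by hydrogen in place of methoxy on an aromatic carbon. Going by the values given here, the one measured step that touches the same ring on the carbonyl carbon, a number 1 percentage points higher from compound 1 to compound 2 (within the scatter), moved nothing beyond the scatter despite a larger swap, so only a small shift is expected here, a number 4 percentage points higher from compound 2 to compound 3 (within the scatter). Compound 3 is therefore estimated at -84%, within a range from -100% to -55%.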

Compound 3, a percentage reported as activity, at one concentration (the size of the read-out at that concentration, not a potency): -65%
The estimate for compound 3 lay 19 percentage points below the measured number; the measured number falls inside the stated range.
By their numbers in this assay, from the lowest: compounds 1 and 2 (each within the scatter of the next); then compound 3.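

In this assay, the ring on the carbonyl carbon turns out not to be indifferent to change: going from 3,4-dimethoxyphenyl to 4-methoxyphenyl gives a number 23 percentage points higher from compound 2 to compound 3 (beyond the scatter) and so weakens the effect, unlike the earlier step on that ring. Methoxy in place of amino on an aromatic carbon gives a number 24 percentage points higher from compound 1 to compound 3 (beyond the scatter) and thus separates 4-methoxyphenyl from 4-aminophenyl as well. Nothing available explains this weakening.

Still open, as far as these compounds go, is how a hydroxyl group, a fluorine or a dimethylamino group would read in place of the lost methoxy.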